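This account rests on a few compounds, and the source may have more. Where it says the series, first, only, none or still open, it means among the compounds named here.

Working notes on the series, read in a functional assay on HepG2 cells (Homo sapiens) for inhibition, read by MTT assay, with a stated time of 24 h; a lower number here means a stronger inhibitor, a higher number a weaker inhibitor. Compound 1 `CC1(C)[C@H]2CC[C@]1(C)N(Cc1cn(-c3cccc(F)c3)nn1)C(=O)C2` gives 80 nM and compound 2 `CC1(C)[C@H]2CC[C@]1(C)N(Cc1cn(-c3ccc(Br)cc3)nn1)C(=O)C2` gives 110 nM, a pair separated by a 1.4-fold higher number from compound 1 to compound 2 (0.14 log units; within the scatter). Compound 3 `Cc1ccc(-n2cc(CN3C(=O)C[C@@H]4CC[C@@]3(C)C4(C)C)nn2)cc1` gives 480 nM, the highest number of the three and so the weakest inhibitor measured here. The gaps to it are a 4.4-fold higher number from compound 2 to compound 3 (0.64 log units; beyond the scatter) and a 6.0-fold higher number from compound 1 to compound 3 (0.78 log units; beyond the scatter).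

Compound 4 `CC1(C)[C@H]2CC[C@]1(C)N(Cc1cn(-c3ccc(Cl)cc3)nn1)C(=O)C2` is the next entry, and its difference is chloro in place of methyl on an aromatic carbon. In words, this is chloro in place of methyl on an aromatic carbon, or 4-methylphenyl to 4-chlorophenyl.

The closest measured change is a 4.4-fold higher number from compound 2 to compound 3 (0.64 log units; beyond the scatter), with methyl in place of bromo on an aromatic carbon. Read in reverse, it points to a lower number on leaving methyl. For the measured compounds named here, the step of a 6.0-fold higher number from compound 1 to compound 3 (0.78 log units; beyond the scatter) runs the same way, and neither of the other two compounds goes against this, but three compounds make a thin basis and no chloro compound has been measured yet. A modest step towards a lower number is therefore expected in this assay, bringing compound 4 near compound 2 at 110 nM. The expected step is a 3.2-fold lower number from compound 3 to compound 4 (0.51 log units; beyond the scatter). For compound 4 the estimate is 150 nM, with an expected range of 60 nM to 400 nM.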

Compound 4, half-maximal inhibitory concentration: 90 nM
Estimate against measurement, compound 4: 1.7-fold (0.22 log units) above, and the stated range covers the measured number.
By their numbers in this assay, from the lowest: compounds 1, 4 and 2 (each within the scatter of the next); then compound 3.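

In this assay, for the compounds shown here, chloro in place of methyl on the aromatic carbon para to a large group gives a clear separation (a 5.3-fold lower number from compound 3 to compound 4 (0.73 log units; beyond the scatter)), so bromo is no longer the only group at this place to stand apart from methyl. Chloro and bromo at this place cannot be told apart (a 1.2-fold lower number from compound 2 to compound 4 (0.09 log units; within the scatter)), and 4-chlorophenyl cannot be told apart from 3-fluorophenyl on the aromatic nitrogen (a 1.1-fold higher number from compound 1 to compound 4 (0.05 log units; within the scatter)), which leaves the 4-methylphenyl compound 3 as the only one of the four set apart from the others, with no compound going against that reading. Nothing on hand offers an explanation for the separation between methyl and the halogens at this place.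

Open, as far as these compounds go, is whether a methoxy, a nitrile, a primary amine or a carboxylic acid at this same place would fall with chloro and bromo or with methyl. Also open, from the compounds shown here alone, is how a single group behaves when moved around the ring, such as 3-chlorophenyl against 4-chlorophenyl, since the only 3-substituted ring here is the 3-fluorophenyl of compound 1, which differs from the others in its group as well.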